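The source may hold more compounds than are shown below. What is called first, only, known or untested is meant among the compounds shown, and "the series" means these compounds.

Compound 1 (`COc1ccc(S(=O)(=O)N2CCc3cccc(-c4ccco4)c32)cc1`): 82 nM
Compound 2 (`COc1ccc(S(=O)(=O)N2CCc3cccc(-c4ccc(N(C)C)cc4)c32)cc1`): 539 nM

In a functional assay on KB cells (Homo sapiens) for inhibition, with a stated time of 72 h (on this read-out lower numbers stand for stronger inhibition and higher numbers for weaker inhibition), compound 2 has the higher of the two numbers. For the measured compounds named here, the only measured step is a 6.6-fold higher number from compound 1 to compound 2 (0.82 log units; beyond the scatter), with 4-(dimethylamino)phenyl in place of furan-2-yl on an aromatic carbon.

The next change leads to compound 3 (`COc1ccc(S(=O)(=O)N2CCc3cccc(-c4ccc(F)cc4)c32)cc1`): fluoro in place of dimethylamino on an aromatic carbon (fluoro in place of dimethylamino on an aromatic carbon, para to a large group). Going by the values given here, no measured step swaps these two groups, so the one step available bears on this change only indirectly. It shows that replacing the aromatic group can shift the number in this assay by a modest amount, and it does not fix a size here. A modest move towards a lower number is expected, smaller than or similar to that step. The expected change is a 2.2-fold lower number from compound 2 to compound 3 (0.33 log units; beyond the scatter), though with wide uncertainty. The estimated value for compound 3 is 250 nM, with an expected range from 70 nM to 800 nM.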

Compound 3, half-maximal inhibitory concentration: 86 nM
Beside the measured number, compound 3's estimate is 2.9-fold (0.46 log units) above it, and the stated range covers the measured number.
By their numbers in this assay, from the lowest: compounds 1 and 3 (each within the scatter of the next); then compound 2.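

In this assay, the weak number of compound 2 does not come from having a six-membered aromatic ring at this place as such. With the ring kept and only the group on it changed, fluoro in place of dimethylamino gives a 6.3-fold lower number from compound 2 to compound 3 (0.80 log units; beyond the scatter), so the group para to a large group matters here. The 4-fluorophenyl and furan-2-yl groups cannot be told apart in this pair, with a 1.0-fold higher number from compound 1 to compound 3 (0.02 log units; within the scatter), and the data offer no explanation for the effect of the dimethylamino group.

The compounds shown leave open how a primary amine, a hydroxyl or a carboxylic acid would read in the same place. They also leave open whether a chloro or methoxy group would stay close to fluoro, or whether fluoro in another place on the ring would do the same.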